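Acetoxy in place of hydrogen: an estimate for compound 4

This account rests on a few compounds, and the source may have more. Where it says the series, first, only, none or still open, it means among the compounds named here.

Compound 1 `O=C1C=CCC/C1=C\C=C\c1ccccc1` is the reference point of the series. Going by the values given here, in a functional assay on HGC-27 cells (Homo sapiens) for cytotoxicity, read by MTT assay, with a stated time of 72 h (a higher number here means a weaker inhibitor, a lower number a stronger inhibitor), compound 1 gives 4500 nM, the lowest of the three numbers so far, though neither of the other two lies beyond the scatter of it: compound 3 `O=C1C=CCC/C1=C\C=C\c1ccc(Cl)cc1` gives 4800 nM and compound 2 `Cc1ccc(/C=C/C=C2\CCC=CC2=O)cc1` gives 8100 nM. The measured steps are a 1.8-fold higher number from compound 1 to compound 2 (0.26 log units; within the scatter) and a 1.1-fold higher number from compound 1 to compound 3 (0.03 log units; within the scatter), and between the two substituted compounds a 1.7-fold lower number from compound 2 to compound 3 (0.23 log units; within the scatter).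

Compound 4 `CC(=O)Oc1ccc(/C=C/C=C2\CCC=CC2=O)cc1` differs from compound 1 as follows: acetoxy in place of hydrogen on an aromatic carbon. Both measured steps from compound 1 concern the same place on the aromatic ring, and both stayed within the scatter, so substitution there has so far left the read-out unmoved. Among the compounds with values here, no measured compound carries an acetoxy group, so the step expected for compound 4 is taken as none beyond the scatter, which means an expected 1.2-fold higher number from compound 1 to compound 4 (0.09 log units; within the scatter). Compound 4 is thus estimated at 5500 nM, expected to fall between 2500 nM and 12000 nM.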

Compound 4, half-maximal inhibitory concentration: 4900 nM
For compound 4 the middle estimate is 1.1-fold (0.05 log units) above the measured one, and the stated range covers the measured number.
By their numbers in this assay, from the lowest: compounds 1, 3, 4 and 2 (each within the scatter of the next).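

Acetoxy extends the flat picture at this position, para to a large group, to an entering group of 4 heavy atoms with 2 hydrogen-bond acceptors: in this assay the change gives a 1.1-fold higher number from compound 1 to compound 4 (0.04 log units; within the scatter) and so stays level with the unsubstituted compound. Exchanging substituents at this place leaves the read-out just as unmoved, with a 1.0-fold higher number from compound 3 to compound 4 (0.01 log units; within the scatter) for acetoxy in place of chloro and a 1.7-fold lower number from compound 2 to compound 4 (0.22 log units; within the scatter) for acetoxy in place of methyl. Methyl, chloro and acetoxy therefore cannot be told apart here, and no supporting measurement speaks to why this read-out stays flat.

Going by these compounds alone, open is whether an amine or a carboxylic acid at this same place would produce the first step beyond the scatter. Also open, as far as these compounds go, is whether changes to the shared core, rather than to this aromatic position, would move the number.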